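The source may report more compounds than this note shows. Statements on the series, on what has been measured and on what is new or still open speak of the compounds shown alone.

Compound 1 `N#Cc1ccccc1COc1ccccc1C(=O)Nc1cccnc1`: 31800 nM
Compound 2 `O=C(Nc1cccnc1)c1ccccc1OCc1c(F)cccc1Cl`: 1500 nM
Compound 3 `O=C(Nc1cccnc1)c1ccccc1OCc1cc(Cl)ccc1Cl`: 990 nM

These numbers come from an assay on lysate for inhibition of phosphatidylcholine:ceramide cholinephosphotransferase 2 (Homo sapiens), read by HPLC, with stated times of 30 min and 2 h; on this read-out higher numbers stand for weaker inhibition and lower numbers for stronger inhibition. Compound 3 has the lowest number of the three; its gap to compound 2 lies within the scatter, while a 32-fold lower number from compound 1 to compound 3 (1.51 log units; beyond the scatter) is a large step. Compound 4 `COc1ccc(Cl)cc1COc1ccccc1C(=O)Nc1cccnc1` differs from compound 3 by methoxy in place of chloro on an aromatic carbon, a methoxy in place of chloro on an aromatic carbon, ortho to a large group and para to a chloro group. Among the measured compounds shown here, no measured step swaps exactly these two groups. For the measured compounds named here, the steps that bear on it, a 21-fold lower number from compound 1 to compound 2 (1.33 log units; beyond the scatter) and a 32-fold lower number from compound 1 to compound 3 (1.51 log units; beyond the scatter), show that the groups on this ring can move the number strongly, whereas a 1.5-fold lower number from compound 2 to compound 3 (0.18 log units; within the scatter) shows little difference between two halogen patterns. The step of a 2.2-fold higher number from compound 3 to compound 4 (0.35 log units; beyond the scatter) is therefore expected to be modest, toward a higher number. Compound 4 is expected to give about 2200 nM, in a range from 700 nM to 7000 nM.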

Compound 4, half-maximal inhibitory concentration: 670 nM
Estimate against measurement, compound 4: 3.3-fold (0.52 log units) above; the measured number lies below the stated range.
By their numbers in this assay, from the lowest: compounds 4, 3 and 2 (each within the scatter of the next, the first and the last beyond it); then compound 1.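

Methoxy can take the place of chloro here, ortho to a large group and para to a chloro group, with the two numbers staying within the scatter of each other (a 1.5-fold lower number from compound 3 to compound 4 (0.17 log units; within the scatter)). The change adds a heavy atom and a hydrogen-bond acceptor, so among the compounds shown, this position is not limited to a halogen. No measurement is available to explain this result. On these data alone, whether ethoxy, an amine or a carboxylic acid would also keep the number level here remains open.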